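The compounds below may be only part of what the source reports. "The series", "measured", "known", "first", "only" and "open" are said of these compounds alone.

Measured so far in a functional assay on A549 cells (Homo sapiens) for inhibition, read by MTT assay, with a stated time of 48 h; on this read-out lower numbers stand for stronger inhibition and higher numbers for weaker inhibition:

compound 1 `O=C(/C=C/c1coc2cc(O)ccc2c1=O)NCc1ccccc1` — > 100000 nM
compound 2 `COc1cccc(NC(=O)/C=C/c2coc3cc(OC)ccc3c2=O)c1` — 12800 nM
compound 3 `Cc1ccc(CNC(=O)/C=C/c2coc3cc(O)ccc3c2=O)cc1` — 17400 nM

The value of compound 1 is a limit of this assay, not a number (the limit of > 100000 nM in this assay, at which 1 of the 3 values shown sits). Of the two numbers shown, compound 2 has the lower one, but compound 2 and compound 3 sit within the scatter of each other, so no order between them is claimed.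

Among the measured compounds shown here, the only measured step runs from compound 1 to compound 3: an at least 5.7-fold lower number from compound 1 to compound 3 (0.75 log units; beyond the scatter). It changes an aromatic carbon on the benzyl side of the amide and says nothing about swapping one aryl group for another on the amide nitrogen.

Compound 4 `COc1ccc2c(=O)c(/C=C/C(=O)Nc3ccc(F)cc3)coc2c1` differs from compound 2 as follows: 4-fluorophenyl in place of 3-methoxyphenyl on an amide-type nitrogen. For the measured compounds named here, no measured pair changes the group on the amide nitrogen, so nothing here sizes such a step, and the working expectation is a change within the scatter in this assay, in no particular direction.

Compound 4 is therefore estimated at 12000 nM, within a range of 4000 nM to 40000 nM, which is expected to mean a step of a 1.1-fold lower number from compound 2 to compound 4 (0.03 log units; within the scatter).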

Compound 4, half-maximal inhibitory concentration: 26800 nM
Compound 4: middle estimate off by 2.2-fold (0.35 log units), on the low side; the range from low to high includes it.
By their numbers in this assay, from the lowest: compounds 2, 3 and 4 (each within the scatter of the next, the first and the last beyond it). At a limit, above all of these: compound 1.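

In this assay, among the compounds shown here, the group on the amide-type nitrogen now has a measured size for the first time: a 2.1-fold higher number from compound 2 to compound 4 (0.32 log units; beyond the scatter), a modest step, with 4-fluorophenyl in place of 3-methoxyphenyl and the rest of the molecule unchanged. For the compounds shown here, the only earlier step changed an aromatic carbon on the benzyl side of the amide and left this position without any measured size, so the aryl group on this nitrogen is now seen to move the read-out, though only slightly beyond the usual scatter. Nothing in the data at hand bears on the reason for this step.

The pair changes both the substituent and its place on the ring, so the compounds shown cannot tell whether the fluorine, the loss of the methoxy group or the new place carries the step; 3-fluorophenyl and 4-methoxyphenyl on the same nitrogen would separate these. Going by these compounds alone, also open is how an amino group or a carboxylic acid on this aryl ring, or a longer chain on the amide-type nitrogen, would read in this assay, given that one pair is all that sizes this position so far.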